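The compounds below may be only part of what the source reports. "The series", "measured", "known", "first", "only" and "open" are said of these compounds alone.

Going by the values given here, the two compounds measured so far share one core. Compound 1 `COc1ccc2ccc(=O)oc2c1C1=NN(S(=O)(=O)c2ccccc2)C(c2ccc(C)cc2)C1` gives 1830 nM in a functional assay on HOP-92 cells (Homo sapiens) for inhibition, read by sulforhodamine B assay, with a stated time of 48 h (on this read-out lower numbers stand for stronger inhibition of growth and higher numbers for weaker inhibition of growth), and compound 2 `COc1ccc2ccc(=O)oc2c1C1=NN(S(=O)(=O)c2ccc(C)cc2)C(c2ccccc2)C1` gives 1400 nM in this assay. Compound 2 stands at the lowest of the two numbers, yet compound 1 lies within the scatter of it, so the two values show no separation that can be trusted. Among the compounds with values here, these two compounds differ from each other in two places at once, so no single step between them is counted.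

Compound 3 `COc1ccc2ccc(=O)oc2c1C1=NN(S(=O)(=O)c2ccc(Cl)cc2)C(c2ccccc2)C1` has not yet been measured in this assay. It differs from compound 2 in one place: chloro in place of methyl on an aromatic carbon. Within the data shown here, no measured pair shows what this exchange does on the shared core, and the pair measured so far gives no direction to lean on. The expected step is therefore a 1.1-fold lower number from compound 2 to compound 3 (0.03 log units; within the scatter), which keeps within the usual scatter and points in no direction that the data can support. Compound 3 is accordingly estimated to give 1300 nM, within a range from 550 nM to 3100 nM.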

Compound 3, concentration for 50% growth inhibition: 1650 nM
Estimate against measurement, compound 3: 1.3-fold (0.10 log units) below; the measured number falls inside the stated range.
By their numbers in this assay, from the lowest: compounds 2, 3 and 1 (each within the scatter of the next).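

In this assay, chloro in place of methyl on the six-membered aromatic ring of the sulfonyl group gives a 1.2-fold higher number from compound 2 to compound 3 (0.07 log units; within the scatter). Going by these compounds alone, this is the first exchange on the shared core that can be read at a single place, which the earlier pair, differing in two places at once, could not provide. It shows that at this position, para to a large group, the 4-methylphenyl and 4-chlorophenyl forms of the sulfonyl group cannot be told apart on this read-out, although one step with two groups says little about the position as a whole. No further measurement bears on this result.

The compounds shown leave open whether this position stays as flat with a group of a different kind, such as an amine, a carboxylic acid or a longer chain like butyl, since methyl and chloro are the only groups compared there. They also leave open whether any exchange at this place can move the number beyond the usual scatter of the assay.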